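The source may hold more compounds than are shown below. What is called first, only, known or untested is meant among the compounds shown, and "the series" means these compounds.

In a functional assay on HOP-62 cells (Homo sapiens) for inhibition, read by sulforhodamine B assay (on this read-out higher numbers stand for weaker inhibition of growth and lower numbers for stronger inhibition of growth), three compounds have been measured so far. Compound 1 (`COc1ccc(-c2ccc(-c3ccc(-c4nc5cc(C)ccc5[nH]4)cc3)cc2)cc1OC`) gives the lowest number at 2120 nM and compound 2 (`FC(F)(F)c1ccc(-c2ccc(-c3ccc(-c4nc5ccccc5[nH]4)cc3)cc2)cc1`) the highest at 100000 nM while compound 3 (`Cc1ccc2[nH]c(-c3ccc(-c4ccc(-c5ccc(F)cc5)cc4)cc3)nc2c1`) stands between them with 33500 nM as the second highest of the three. Compound 4 (`Cc1ccc2[nH]c(-c3ccc(-c4ccc(-c5ccc(C(F)(F)F)cc5)cc4)cc3)nc2c1`) has not yet been measured. It departs from compound 3 at a single place, with trifluoromethyl in place of fluoro on an aromatic carbon para to a large group.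

Within the data shown here, only one measured step touches that place. It runs a 16-fold higher number from compound 1 to compound 3 (1.20 log units; beyond the scatter) with 4-fluorophenyl replacing 3,4-dimethoxyphenyl, a large change that shows this position can matter in this assay but involves a different pair of groups. Among the measured compounds shown here, no measured pair exchanges fluoro for trifluoromethyl directly. The closest evidence is compound 2 at 100000 nM on a core that differs from that of compound 4, since it also carries 4-(trifluoromethyl)phenyl. A small move toward a higher number is therefore expected, with a 2.1-fold higher number from compound 3 to compound 4 (0.32 log units; beyond the scatter) as the estimated step in this assay and weaker inhibition of growth as its meaning. Compound 4 is estimated at 70000 nM with an expected range from 25000 nM to 130000 nM in this estimate.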

Compound 4, concentration for 50% growth inhibition: 24200 nM
The estimate for compound 4 lay 2.9-fold (0.46 log units) above the measured number, outside the stated range (below it).
By their numbers in this assay, from the lowest: compound 1; then compounds 4 and 3 (each within the scatter of the next); then compound 2.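

At this place, on an aromatic carbon para to a large group, fluoro and trifluoromethyl cannot be told apart in this assay (a 1.4-fold lower number from compound 3 to compound 4 (0.14 log units; within the scatter)), while the 3,4-dimethoxyphenyl group stands clearly apart from both (a 16-fold higher number from compound 1 to compound 3 (1.20 log units; beyond the scatter) and an 11-fold higher number from compound 1 to compound 4 (1.06 log units; beyond the scatter)). The new compound also shows that a change elsewhere in the molecule can register beyond the scatter when the 4-(trifluoromethyl)phenyl group stays in place: methyl in place of hydrogen on an aromatic carbon gives a modest step (a 4.1-fold lower number from compound 2 to compound 4 (0.62 log units; beyond the scatter)). No measurement bears on why these numbers fall as they do.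

As far as these compounds go, what an amine or a carboxylic acid at this aromatic carbon would do remains open, as does whether a single methoxy group would stand with the 3,4-dimethoxyphenyl group or with the fluoro and trifluoromethyl pair. From the compounds shown here alone, it is also open whether methyl in place of hydrogen would give a step of similar size with 3,4-dimethoxyphenyl or 4-fluorophenyl in place of 4-(trifluoromethyl)phenyl.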